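The source may report more compounds than this note shows. Statements on the series, on what has been measured and on what is new or still open speak of the compounds shown alone.

Measured in a functional assay on Raji cells (Homo sapiens) for antiproliferative activity, read by MTT assay, with a stated time of 72 h; a lower number here means a stronger inhibitor, a higher number a weaker inhibitor:
compound 1 `Cc1cccc(CN2CCC(c3noc(CN(C)c4ncc(C(=O)NO)cn4)n3)CC2)c1`: 47.3 nM
compound 2 `CN(Cc1nc(C2CCN(Cc3ccc(C(F)(F)F)cc3)CC2)no1)c1ncc(C(=O)NO)cn1`: 207 nM

Among the compounds with values here, compound 2, at 207 nM, holds the higher of the two numbers so far. Compound 3 `CN(Cc1nc(C2CCN(Cc3ccc(F)cc3Cl)CC2)no1)c1ncc(C(=O)NO)cn1` is not yet measured. Its difference from compound 2 is 2-chloro-4-fluorophenyl in place of 4-(trifluoromethyl)phenyl on a saturated chain carbon bound to an amine nitrogen in a ring.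

Within the data shown here, only one measured step bears on this change: a 4.4-fold higher number from compound 1 to compound 2 (0.64 log units; beyond the scatter), a modest step beyond the scatter, made at the same place. The group that entered there now leaves. Compound 1, with 3-methylphenyl at that place, gives 47.3 nM, so the expectation leans from compound 2 towards that number. One step sets no rule for the entering group, so the lean is weak. The expected step is a 2.1-fold lower number from compound 2 to compound 3 (0.32 log units; beyond the scatter), smaller than the measured one and uncertain in size. Compound 3 is estimated at 100 nM, with an expected range of 35 nM to 290 nM.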

Compound 3, half-maximal inhibitory concentration: 116 nM
Compound 3: middle estimate off by 1.2-fold (0.06 log units), on the low side; the measured number falls inside the stated range.
By their numbers in this assay, from the lowest: compound 1; then compounds 3 and 2 (each within the scatter of the next).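

In this assay, the change at this place, on a saturated chain carbon bound to an amine nitrogen in a ring, gives a 1.8-fold lower number from compound 2 to compound 3 (0.25 log units; within the scatter) and so does not separate 2-chloro-4-fluorophenyl from 4-(trifluoromethyl)phenyl. Against 3-methylphenyl, the same place gives a 2.5-fold higher number from compound 1 to compound 3 (0.39 log units; beyond the scatter) and this leaves compound 1 the strongest inhibitor of the three, since its steps to both others now lie beyond the scatter. No measurement shown gives a reason for the standing of 3-methylphenyl at this place.

Still open, going by these compounds, is how an unsubstituted phenyl, a pyridyl or a cyclohexyl would stand at this place relative to compound 1. Also open, on these data alone, is whether a basic amine or a carboxylic acid on the aromatic ring would be accepted here.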